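A few compounds are considered here, and "the series" means these few. Any claim that something is new, unique, unknown or untested is made for them only; others in the source may bear on it.

Of the compounds shown here, two that share the same amide core have been tested in an assay on HEK293 cells for antagonist activity at transient receptor potential cation channel subfamily V member 2 (Rattus norvegicus), read by fluorescence and calcium flux, with a stated time of 5 min; a lower number here means a stronger inhibitor, a higher number a weaker inhibitor. Compound 1 `CCCCC/C=C\C/C=C\CCCCCCCC[Se]CCC(=O)NCc1ccc(O)c(OC)c1` carries a long chain with two double bonds and a selenium atom in it; in this assay compound 1 gives 1400 nM, the only number shown. Compound 2 `CCCCCCC(=O)C/C=C/CCCCCCCC(=O)NCc1ccc(O)c(OC)c1` has a chain with a ketone and no selenium; in this assay compound 2 reaches only a limit, > 10000 nM, so it sits at the limit of > 10000 nM in this assay, at which 1 of the 2 values shown sits. Compound 3 `CCCCCC[C@@H](O)C/C=C\CCCCCCCC[Se]CCC(=O)NCc1ccc(O)c(OC)c1` is compound 1 changed in one place: 1-hydroxyheptyl in place of hept-1-en-1-yl on a saturated chain carbon bound to a double-bonded chain carbon. Within the data shown here, no measured pair shows this change on its own, so there is no step to lean on. The step from compound 1 to compound 3 is expected to be a modest weakening, a 2.1-fold higher number from compound 1 to compound 3 (0.33 log units; beyond the scatter), perhaps no larger than the scatter. In this assay compound 3 is estimated at 3000 nM, with a range from 1000 nM to 10000 nM.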

Compound 3, half-maximal inhibitory concentration: > 10000 nM
Compound 3: only a limit was reported (the forecaster's own chance of this, stated with the estimate: 25%); middle value at least 3.3-fold (0.52 log units) from the limit.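

Among these compounds, this is the first reading at this position. In this assay, 1-hydroxyheptyl in place of hept-1-en-1-yl on a saturated chain carbon bound to a double-bonded chain carbon gives an at least 7.1-fold higher number from compound 1 to compound 3 (0.85 log units; beyond the scatter), so this single change weakens compound 1 by more than the usual scatter. The step gives only a minimum size, and the entry for compound 3 is a limit, not a number, the same limit reached elsewhere in the set: the limit of > 10000 nM in this assay, at which 2 of the 3 values shown sit.

The compounds shown leave open whether the loss follows the added hydroxyl group, the removed double bond or the defined stereocentre, and whether the mirror-image alcohol would read the same. They also leave open how an amine or a carboxylic acid in place of the hydroxyl would read in this assay.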